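Ester versus acid across two cores in a cytotoxicity series

A few compounds are considered here, and "the series" means these few. Any claim that something is new, unique, unknown or untested is made for them only; others in the source may bear on it.

Compound 1 `C=C1CC[C@@H]2[C@](C)(CCC[C@]2(C)C(=O)O)[C@H]1CCc1ccc2c(OC(C)=O)ccc(OC(C)=O)c2c1` is the parent acid; in a functional assay on HT-29 cells (Homo sapiens) for cytotoxicity, read by sulforhodamine B assay, with a stated time of 72 h (a higher number here means a weaker inhibitor of growth, a lower number a stronger inhibitor of growth), compound 1 gives 240 nM. Its methyl ester, compound 2 `C=C1CC[C@@H]2[C@](C)(CCC[C@]2(C)C(=O)OC)[C@H]1CCc1ccc2c(OC(C)=O)ccc(OC(C)=O)c2c1`, differs by methyl in place of hydrogen on an oxygen next to a carbonyl group and in this assay compound 2 gives 500 nM, so the step of a 2.1-fold higher number from compound 1 to compound 2 (0.32 log units; beyond the scatter) is modest but beyond the scatter. Compound 3 `C=C1CC[C@@H]2[C@](C)(CCC[C@]2(C)C(=O)O)[C@H]1CCC1=CCc2c(OC(C)=O)ccc(OC(C)=O)c2C1` carries a different core; the difference between the two cores is not broken down here. In this assay compound 3 gives 10100 nM, the highest number of the three measured compounds and well beyond the scatter from compound 1 and compound 2.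

Compound 4 `C=C1CC[C@@H]2[C@](C)(CCC[C@]2(C)C(=O)OC)[C@H]1CCC1=CCc2c(OC(C)=O)ccc(OC(C)=O)c2C1` is the methyl ester of compound 3 and differs from it by methyl in place of hydrogen on an oxygen next to a carbonyl group, the same change as that from compound 1 to compound 2, made at the same kind of place. Among the compounds with values here, the step is expected to be a 2.0-fold higher number from compound 3 to compound 4 (0.30 log units; within the scatter), resting on the single earlier instance a 2.1-fold higher number from compound 1 to compound 2 (0.32 log units; beyond the scatter) and on the starting point given by compound 3 with 10100 nM. Compound 4 is thus estimated at 20000 nM in this assay, with a range from 8000 nM to 50000 nM expected.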

Compound 4, concentration for 50% growth inhibition: 1380 nM
The estimate for compound 4 lay 14-fold (1.16 log units) above the measured number; the measured number lies below the stated range.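

In this assay, carboxy to methoxycarbonyl gives a 7.3-fold lower number from compound 3 to compound 4 (0.86 log units; beyond the scatter), which runs opposite in direction to the step seen on the other core. In these two pairs, the outcome of the change therefore depends on the core, in direction as well as in size: the same change on two cores in this assay, a 2.1-fold higher number (0.32 log units; beyond the scatter) from compound 1 to compound 2 and a 7.3-fold lower number (0.86 log units; beyond the scatter) from compound 3 to compound 4, 15-fold (1.18 log units) apart, beyond the scatter of two such steps

Within the data shown here, this rests on only two pairs and does not show which part of the difference between the cores governs the outcome, nor why the direction reverses; for now, a step read on one core gives no usable estimate for the same change on the other.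

From the compounds shown here alone, it remains open whether an ethyl ester or a primary amide in place of the carboxylic acid would follow the methyl ester on each core, or would separate the two cores in the same way. Going by these compounds, it is also open whether free hydroxy groups in place of the acetoxy groups would keep the gap between the two steps.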